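The source may report more compounds than this note shows. Statements on the series, on what has been measured and on what is new or still open speak of the compounds shown alone.

Measured so far in a functional assay with Oryctolagus cuniculus as the target; on this read-out higher numbers stand for weaker inhibition and lower numbers for stronger inhibition:
compound 1 `COc1ccc(-c2nc(/N=C(\N)n3ccnc3)sc2-c2ccc(OC)cc2)cc1` gives > 100 nM, which is a limit of the assay and not a number.
compound 2 `COc1ccc(-c2nc(CNC(=O)CSC)sc2-c2ccc(OC)cc2)cc1` gives < 100 nM, again a limit of the assay and not a number.

Compound 2 therefore stands at the limit on the side of stronger inhibition in this assay, with its exact number unknown. Compound 3 `COc1ccc(-c2nc(CCC(=O)O)sc2-c2ccc(OC)cc2)cc1` differs from compound 2 by carboxymethyl in place of (((methylsulfanyl)methyl)carbonyl)amino on a saturated chain carbon bound to an aromatic carbon. Going by the values given here, the one measured step, a number no higher from compound 1 to compound 2 (the limit leaves the size open), rests on the limit of > 100 nM in this assay, at which 1 of the 2 values shown sits, and (the limit of < 100 nM in this assay, at which 1 of the 2 values shown sits), so its size is open, and it changes a different group. Among the compounds with values here, no measured step bears on the present change, so only a loose expectation is possible. For compound 3 the expected step is an at least 2.0-fold higher number from compound 2 to compound 3 (0.30 log units; that floor lies within the scatter). Compound 3 is estimated at 200 nM, between 20 nM and 2000 nM.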

Compound 3, half-maximal inhibitory concentration: < 100 nM
Compound 3 ended at the assay's limit (the forecaster's own chance of this, stated with the estimate: 50%); at least 2.0-fold (0.30 log units) between middle value and limit.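

Carboxymethyl on this saturated chain carbon keeps the compound on the stronger side of the limit, so the (((methylsulfanyl)methyl)carbonyl)amino group is not needed to stay there. In this assay, the change on the aromatic carbon gives a number no higher from compound 1 to compound 3 (the limit leaves the size open). The step between compound 2 and compound 3 cannot be read, because both end at one limit and neither has an exact number: the limit of < 100 nM in this assay, at which 2 of the 3 values shown sit.

As far as these compounds go, how far either compound lies past that limit remains open. So does whether an amine or a longer chain here would stay on the same side.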